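Chloro on the benzoyl group of compound 2

A few compounds are considered here, and "the series" means these few. Any claim that something is new, unique, unknown or untested is made for them only; others in the source may bear on it.

Measured in a functional assay on K562 cells (Homo sapiens) for antiproliferative activity, read by MTT assay (a higher number here means a weaker inhibitor, a lower number a stronger inhibitor), as follows:
compound 1 `N#Cc1c(Cl)c(Cl)c(C(C(=O)c2ccccc2)=C2NCCN2)c(C#N)c1Cl` gives 8.5 ug/mL
compound 2 `N#Cc1c(F)c(F)c(C(C(=O)c2ccccc2)=C2NCCN2)c(C#N)c1F` gives 19.6 ug/mL
compound 3 `N#Cc1c(F)c(C#N)c(C(C(=O)c2ccccc2)=C2NCCN2)c(F)c1Nc1ccccc1` gives 5.6 ug/mL

In this assay compound 2 has the highest number of the three at 19.6 ug/mL, and compound 1 and compound 3 both lie lower, beyond the scatter. Compound 4 `N#Cc1c(F)c(F)c(C(C(=O)c2ccc(Cl)cc2)=C2NCCN2)c(C#N)c1F` differs from compound 2 by one change, (chloro in place of hydrogen on an aromatic carbon), which turns benzoyl into (4-chlorophenyl)carbonyl. Within the data shown here, no measured step covers this change. Among the measured compounds shown here, the only measured step is a 3.5-fold lower number from compound 2 to compound 3 (0.54 log units; beyond the scatter), a modest one, for anilino in place of fluoro at a different place in the molecule, so it bears on the new compound only indirectly. The data therefore support a small expected move at most, leaning towards a lower number, since neither other compound lies above compound 2. The expected change is a 1.5-fold lower number from compound 2 to compound 4 (0.18 log units; within the scatter). For compound 4 the estimated value is 13 ug/mL, with an expected range from 6 ug/mL to 27 ug/mL.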

Compound 4, half-maximal inhibitory concentration: 1.8 ug/mL
For compound 4 the middle estimate is 7.2-fold (0.86 log units) above the measured one, outside the stated range (below it).
By their numbers in this assay, from the lowest: compound 4; then compounds 3 and 1 (each within the scatter of the next); then compound 2.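

In this assay, the phenyl of the benzoyl group proves to be a highly responsive site: chloro in place of hydrogen, para to a large group, gives an 11-fold lower number from compound 2 to compound 4 (1.04 log units; beyond the scatter). Among these compounds, until now, this phenyl carried no substituent in any compound, and the only measured single-place step, on the other aromatic ring, was a modest one: a 3.5-fold lower number from compound 2 to compound 3 (0.54 log units; beyond the scatter). No available measurement bears on why this chloro has so large an effect.

The compounds shown leave open whether the drop in the number is specific to chloro or would also appear with fluoro, methoxy or an amino group in the same place. They also leave open whether 4-chlorophenyl would give a similar step on the core of compound 1 or compound 3.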